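Swapping the aromatic group on a soluble compound

This account rests on a few compounds, and the source may have more. Where it says the series, first, only, none or still open, it means among the compounds named here.

Measured in a physicochemical assay for solubility, in phosphate buffer, at pH 7.4; a higher number here means a more soluble compound, a lower number a less soluble compound:
- Compound 1 `N#Cc1ccc(-c2nccnc2OC2CN(c3ccc4ccccc4n3)C2)cc1`: < 1000 nM, a limit of the assay and not a number.
- Compound 2 `Cc1ncccc1-c1nccnc1OC1CN(c2ccc3ccccc3n2)C1`: 253000 nM

Among the compounds with values here, compound 2 holds the only true number so far, and the measured step to it is upward. Compound 3 `CS(=O)(=O)N1CCC(c2nccnc2OC2CN(c3ccc4ccccc4n3)C2)CC1` brings a new change: 1-(methylsulfonyl)piperidin-4-yl in place of 2-methylpyridin-3-yl on an aromatic carbon. Within the data shown here, one measured step bears on it: an at least 250-fold higher number from compound 1 to compound 2 (2.40 log units; beyond the scatter). This step is large and beyond the scatter, and its size rests on (the limit of < 1000 nM in this assay, at which 1 of the 2 values shown sits). It shows that swapping the group on this aromatic carbon can move the read-out strongly, so another large step, this time downward, is expected. The expected change is a 17-fold lower number from compound 2 to compound 3 (1.23 log units; beyond the scatter). Compound 3 is estimated at 15000 nM, within an expected range of 1500 nM to 150000 nM.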

Compound 3, solubility: 181000 nM
Beside the measured number, compound 3's estimate is 12-fold (1.08 log units) below it; measured number outside the range, above it.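

In this assay, a high number on this aromatic carbon does not need an aromatic group: compound 2 and compound 3 carry an aromatic and a non-aromatic ring, yet their values lie close together (a 1.4-fold lower number from compound 2 to compound 3 (0.15 log units; within the scatter)). From the compounds shown here alone, only 4-cyanophenyl stands apart so far (an at least 180-fold higher number from compound 1 to compound 3 (2.25 log units; beyond the scatter)), and the true size of that step stays unknown: the limit of < 1000 nM in this assay, at which 1 of the 3 values shown sits.

The compounds shown leave open how a plain phenyl ring would read here, which would separate the ring from its nitrile. They also leave open how an open-chain amine or a carboxylic acid would behave on this carbon.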